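Working notes: from compound 2 to compound 3

This account rests on a few compounds, and the source may have more. Where it says the series, first, only, none or still open, it means among the compounds named here.

- compound 1 `CC(=O)c1ccc(Oc2ccccc2NC(C)=C2C(=O)CC(c3ccccc3)CC2=O)cc1` in a functional assay on HMEC-1 cells (Homo sapiens) for antiproliferative activity, read by cell counting, with a stated time of 4 days (a lower number here means a stronger inhibitor, a higher number a weaker inhibitor), gives 180 nM
- compound 2 `CC(Nc1ccccc1Oc1ccc(C(C)O)cc1)=C1C(=O)CC(c2ccccc2)CC1=O` in this assay gives 140 nM

Compound 2 stands level with compound 1 within the scatter, and these two numbers are the only ones available in the series. The next structure, compound 3 (`CC(Nc1ccccc1Oc1cccc(N)c1)=C1C(=O)CC(c2ccccc2)CC1=O`), carries 3-aminophenyl in place of 4-(1-hydroxyethyl)phenyl on an oxygen on an aromatic ring. Within the data shown here, the one measured step (a 1.3-fold lower number from compound 1 to compound 2 (0.11 log units; within the scatter)) lies within the scatter and covers only 1-hydroxyethyl in place of acetyl. Among the measured compounds shown here, no measured step covers a change of this kind, so the data give no direction for it. The expected step is therefore none beyond the scatter in this assay (a 1.4-fold higher number from compound 2 to compound 3 (0.15 log units; within the scatter)), with a wide margin. For compound 3 the estimated value is 200 nM (expected range 60 nM to 700 nM).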

Compound 3, half-maximal inhibitory concentration: 41 nM
For compound 3 the middle estimate is 4.9-fold (0.69 log units) above the measured one; measured number outside the range, below it.
By their numbers in this assay, from the lowest: compound 3; then compounds 2 and 1 (each within the scatter of the next).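

In this assay, the group on an oxygen on an aromatic ring can move the number beyond the scatter: 3-aminophenyl in place of 4-(1-hydroxyethyl)phenyl gives a modest gain (a 3.4-fold lower number from compound 2 to compound 3 (0.53 log units; beyond the scatter)), and 3-aminophenyl in place of 4-acetylphenyl gives one of similar standing (a 4.4-fold lower number from compound 1 to compound 3 (0.64 log units; beyond the scatter)). The earlier step (a 1.3-fold lower number from compound 1 to compound 2 (0.11 log units; within the scatter)) stayed within the scatter, whereas this larger exchange does not, even though the leaving 4-(1-hydroxyethyl)phenyl and the entering 3-aminophenyl match in hydrogen-bond donors and acceptors. No measurement available here accounts for the gain.

The group names show that both the substituent and its number on the ring change together, so the contributions of the two remain unseparated. Also open, as far as these compounds go, is whether a hydroxyl, a carboxylic acid or an amide in place of the amine would give a similar number.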